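A few compounds are considered here, and "the series" means these few. Any claim that something is new, unique, unknown or untested is made for them only; others in the source may bear on it.

Compound 1 `Cc1cc2c(F)c(Oc3ncnc(N)c3/C=N/OCCCO)ccc2[nH]1` was tested in a functional assay on A-375 cells (Homo sapiens) for antiproliferative activity (a higher number here means a weaker inhibitor, a lower number a stronger inhibitor), where compound 1 gives 336 nM. Among the three compounds measured so far, compound 1 stands second highest: compound 2 `Cc1cc2c(F)c(Oc3ncnc(N)c3/C=N/OCc3ccccc3)ccc2[nH]1` gives 62 nM, and compound 3 `CO/N=C/c1c(N)ncnc1Oc1ccc2ncccc2c1`, built on a different core, gives 1830 nM. Within the data shown here, the only measured change at a single place is the one from compound 1 to compound 2, a 5.4-fold lower number from compound 1 to compound 2 (0.73 log units; beyond the scatter), where the 2-hydroxyethyl gives way to phenyl. Compound 4 `Cc1cc2c(F)c(Oc3ncnc(N)c3/C=N/OCC3CCCCC3)ccc2[nH]1` has not yet been measured. It differs from compound 1 as follows: cyclohexyl in place of 2-hydroxyethyl on a saturated chain carbon bound to an oxygen. Among the measured compounds shown here, this change resembles the step to compound 2, since in both cases the 2-hydroxyethyl is exchanged for a ring, although here the ring is non-aromatic rather than aromatic, and only one such step has been seen. A lower number is therefore expected, of a size close to the earlier step but with wide uncertainty. Compound 4 is expected to give 90 nM, within a range from 35 nM to 250 nM. For compound 4 the expected step is a 3.7-fold lower number from compound 1 to compound 4 (0.57 log units; beyond the scatter).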

Compound 4, half-maximal inhibitory concentration: 4920 nM
Compound 4: the middle estimate sits 55-fold (1.74 log units) below what was measured; the measured number lies above the stated range.
By their numbers in this assay, from the lowest: compound 2; then compound 1; then compound 3; then compound 4.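

In this assay, placing a ring on a saturated chain carbon bound to an oxygen does not by itself lower the number. Cyclohexyl in place of 2-hydroxyethyl brings a 15-fold higher number from compound 1 to compound 4 (1.17 log units; beyond the scatter) and so runs opposite to the change seen with phenyl. Comparing the two rings directly, cyclohexyl in place of phenyl brings a 79-fold higher number from compound 2 to compound 4 (1.90 log units; beyond the scatter) at the same place, so among these compounds the kind of ring matters, not merely the presence of one, and no measurement shown explains this difference.

The compounds shown leave open whether a plain hydrocarbon chain such as n-butyl would follow cyclohexyl or 2-hydroxyethyl. They also leave open whether a nitrogen-containing ring such as pyridine would keep the low number seen with phenyl.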